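Amide versus urea on a shared pyrazole-bearing core

The source may report more compounds than this note shows. Statements on the series, on what has been measured and on what is new or still open speak of the compounds shown alone.

Compounds measured in a functional assay on UO-31 cells (Homo sapiens) for inhibition, read by sulforhodamine B assay, with a stated time of 48 h; a lower number here means a stronger inhibitor of growth, a higher number a weaker inhibitor of growth:
- compound 1, `COc1cc(-c2nn(-c3cccc(NC(=O)c4cccc(C(F)(F)F)c4)c3)cc2-c2ccncc2)ccc1Cl`: compound 1 gives > 50000 nM, which is a limit of the assay and not a number.
- compound 2, `COc1cc(-c2nn(-c3cccc(NC(=O)Nc4cccc(C(F)(F)F)c4)c3)cc2-c2ccncc2)ccc1Cl`: compound 2 gives 3210 nM.
- compound 3, `COc1cc(-c2nn(-c3cccc(NC(=O)c4ccc(Cl)c(C(F)(F)F)c4)c3)cc2-c2ccncc2)ccc1Cl`: compound 3 gives > 32500 nM, again a limit of the assay rather than a number.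

Compound 3 thus stands only as a limit in this assay, and one further value among the three, that of compound 1, is also a limit. Against the urea, the step of an at least 10-fold higher number from compound 2 to compound 3 (1.00 log units; beyond the scatter) is at least modest, while the step that the two limits leave unreadable from compound 1 to compound 3 cannot be read because both ends sit at limits, the limit of > 32500 nM in this assay, at which 1 of the 3 values shown sits, and (the limit of > 50000 nM in this assay, at which 1 of the 3 values shown sits).

Compound 4, `COc1cc(-c2nn(-c3cccc(NC(=O)c4ccccc4)c3)cc2-c2ccncc2)ccc1Cl`, differs from compound 3 by phenyl in place of 4-chloro-3-(trifluoromethyl)phenyl on a carbonyl carbon. For the measured compounds named here, the steps that bear on this change are the unreadable one from compound 1 to compound 3 and the modest-or-larger one from compound 2 to compound 3; both amides measured so far sit at limits. The expected step that the limit leaves unreadable from compound 3 to compound 4 is therefore none beyond the scatter, with compound 4 most likely again reported as a limit. Compound 4 is estimated at 50000 nM, in the range 15000 nM to 150000 nM.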

Compound 4, concentration for total growth inhibition: > 100000 nM
Compound 4: no number, only a limit; the forecaster's own chance of this, stated with the estimate: 70%; middle value at least 2.0-fold (0.30 log units) from the limit.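

In this assay compound 4 gives > 100000 nM, which is a limit of the assay and not a number. For the compounds shown here, with plain phenyl on the carbonyl carbon, a third amide thus sits at a limit, so neither the trifluoromethyl group nor the added chloro is needed for that outcome, and the step of an at least 31-fold higher number from compound 2 to compound 4 (1.49 log units; beyond the scatter) leaves compound 2, the urea, as the only one of the four compounds with a number. The steps from compound 3 to compound 4 and from compound 1 to compound 4 cannot be read because both ends of each sit at limits: the limit of > 100000 nM in this assay, at which 1 of the 4 values shown sits.

Going by these compounds, how the three amides rank among themselves therefore remains open. Also open, on these data alone, is whether a urea carrying plain phenyl, or a sulfonamide or carbamate in place of the amide, would give a number.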